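The compounds below may be only part of what the source reports. "The series", "measured", "known", "first", "only" and "open" are said of these compounds alone.

Compound 2 `O=C(c1ccc(Cl)cc1)N1CCC(NS(=O)(=O)c2cc(S(=O)(=O)c3ccccc3)ccc2C(F)(F)F)CC1` gives 3100 nM in a physicochemical assay for solubility (a higher number here means a more soluble compound, a lower number a less soluble compound), the lowest of the three numbers measured. Compound 1 `O=C(c1ccccc1)N1CCC(NS(=O)(=O)c2cc(S(=O)(=O)c3ccccc3)ccc2C(F)(F)F)CC1` gives 12500 nM, and compound 3 `CN(C)c1ccc(C(=O)N2CCC(NS(=O)(=O)c3cc(S(=O)(=O)c4ccccc4)ccc3C(F)(F)F)CC2)cn1` gives 12500 nM. Compound 4 `N#Cc1cccc(S(=O)(=O)N2CCC(NS(=O)(=O)c3cc(S(=O)(=O)c4ccccc4)ccc3C(F)(F)F)CC2)c1` has not been measured; it differs from compound 2 by (3-cyanophenyl)sulfonyl in place of (4-chlorophenyl)carbonyl on an amine nitrogen in a ring. Among the measured compounds shown here, two measured steps bear on this: a 4.0-fold lower number from compound 1 to compound 2 (0.61 log units; beyond the scatter), and a 4.0-fold higher number from compound 2 to compound 3 (0.61 log units; beyond the scatter). Both show that removing the chloro from the aromatic carbon, or swapping the whole aromatic group on the carbonyl carbon, shifted the number by a modest amount. For the measured compounds named here, no measured pair tests a sulfonyl in place of a carbonyl on that ring nitrogen, so compound 4 is expected to show a modest rise, a 2.6-fold higher number from compound 2 to compound 4 (0.41 log units; beyond the scatter), with an estimated value of 8000 nM in a range from 2500 nM to 25000 nM.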

Compound 4, solubility: 6300 nM
The estimate for compound 4 lay 1.3-fold (0.10 log units) above the measured number; the measured number falls inside the stated range.
By their numbers in this assay, from the lowest: compound 2; then compounds 4, 1 and 3 (each within the scatter of the next).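

In this assay, a sulfonyl link on this ring nitrogen is compatible with a number in the same range as the carbonyl compounds: a 2.0-fold higher number from compound 2 to compound 4 (0.31 log units; beyond the scatter). Against the two compounds without chlorine, the change stays inside the usual noise: a 2.0-fold lower number from compound 1 to compound 4 (0.30 log units; within the scatter), and a 2.0-fold lower number from compound 3 to compound 4 (0.30 log units; within the scatter). No measurement shown here explains these steps.

The compounds shown leave open whether the sulfonyl, the nitrile or the loss of chlorine carries the step from compound 2, as all three change together. A (4-chlorophenyl)sulfonyl group on the same nitrogen would separate them.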